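Swapping pyridine attachment points on a shared core

The compounds below may be only part of what the source reports. "The series", "measured", "known", "first", "only" and "open" are said of these compounds alone.

Of the compounds shown here, three that share one core have been tested in a functional assay on CHO cells for positive allosteric modulation of muscarinic acetylcholine receptor M5 (Homo sapiens), read by FLIPR and calcium flux, with a stated time of 1 h; a higher number here means that more compound is needed for the effect, a lower number that less compound is needed. Compound 1 is `O=C1C(=O)N(Cc2ccc(-c3ccncc3)cn2)c2ccc(OC(F)(F)F)cc21`. Compound 2 is `O=C1C(=O)N(Cc2ccc(-c3ccncc3)nc2)c2ccc(OC(F)(F)F)cc21`, and compound 3 is `O=C1C(=O)N(Cc2ccc(-c3cccnc3)cn2)c2ccc(OC(F)(F)F)cc21`. The cores of compound 1 and compound 2 differ, but that difference is not broken down here.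

In this assay compound 1 reaches only a limit of the assay, > 30000 nM. Compound 3 likewise gives only a limit, > 30000 nM. Among the compounds with values here, compound 2 is the one compound with a real number, giving 4400 nM in this assay.

Compound 3 comes from compound 1 by pyridin-3-yl in place of pyridin-4-yl on an aromatic carbon. The size of this step cannot be read, a step that the two limits leave unreadable from compound 1 to compound 3, because of the limit of > 30000 nM in this assay, at which 2 of the 3 values shown sit.

Compound 4, `O=C1C(=O)N(Cc2ccc(-c3cccnc3)nc2)c2ccc(OC(F)(F)F)cc21`, has not yet been measured. It comes from compound 2 by pyridin-3-yl in place of pyridin-4-yl on an aromatic carbon. This is the same kind of change as from compound 1 to compound 3, but the place differs: in compound 4 the new group stands next to the ring nitrogen, while in compound 3 it stands two atoms from the ring nitrogen.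

Within the data shown here, since the only measured example of this change, from compound 1 to compound 3, gives no readable size, the expectation for compound 4 can rest only on the starting point, compound 2 at 4400 nM, and must be wide. The step from compound 2 to compound 4 is expected to be modest, a 2.0-fold higher number from compound 2 to compound 4 (0.31 log units; beyond the scatter). Compound 4 is therefore estimated at 9000 nM, within a band from 2500 nM to 30000 nM.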

Compound 4, half-maximal effective concentration: 4000 nM
The estimate for compound 4 lay 2.3-fold (0.35 log units) above the measured number; measured number inside the range.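

On the core of compound 2, the swap of pyridin-4-yl for pyridin-3-yl next to the ring nitrogen gives a 1.1-fold lower number from compound 2 to compound 4 (0.04 log units; within the scatter) in this assay and so leaves no measurable difference between these two groups on this core. The same swap on the core of compound 1 has no size that can be read, since compound 1 and compound 3 both give only a limit of the assay, and this is because of the following: the limit of > 30000 nM in this assay, at which 2 of the 4 values shown sit. The series therefore offers just one readable example of this change, which shows that it is tolerated on the core of compound 2 but does not show whether the same holds on the core of compound 1, nor whether it would hold on any further core.

The compounds shown carry only pyridin-4-yl or pyridin-3-yl at this place, so the reading of pyridin-2-yl, a plain phenyl ring, an amine or a carboxylic acid there stays open. On these data alone, the trifluoromethoxy group is also the same throughout, so it remains unknown how a swap of that group, for example to a chloro group, would read in this assay on either core.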